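Aryl swap at compound 1: oxazolyl to pyridinyl

A few compounds are considered here, and "the series" means these few. Any claim that something is new, unique, unknown or untested is made for them only; others in the source may bear on it.

Compound 1 `Cc1cc(-c2c(CCc3ccccc3)c3cc(OCC(=O)NC(C)(C)c4ccccc4)ccc3[nH]c2=O)on1` is the reference point of the series. In a functional assay on CHO cells for antagonist activity at adenosine receptor A2b (Homo sapiens), read by cAMP accumulation, with stated times of 15 min and 1 h (on this read-out higher numbers stand for weaker inhibition and lower numbers for stronger inhibition), compound 1 gives 31 nM, the lowest of the three numbers at hand. Compound 3 `COCCCNC(=O)COc1ccc2c(c1)c(CCc1ccccc1)c(-c1ccc(F)cc1F)c(=O)n2C` gives 633 nM in this assay, and compound 2 `CS(=O)(=O)c1c(CCc2ccccc2)c2cc(OCC(=O)Nc3ccccc3)ccc2[nH]c1=O` gives 1680 nM. Both gaps to compound 1 lie beyond the scatter, so compound 1 is the most potent of the three, although neither of the other two differs from it in a single place.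

Compound 4 `CC(C)(NC(=O)COc1ccc2[nH]c(=O)c(-c3ccccn3)c(CCc3ccccc3)c2c1)c1ccccc1` differs from compound 1 in one place: pyridin-2-yl in place of 3-methyl-1,2-oxazol-5-yl on an aromatic carbon. One aromatic ring with one hetero atom replaces one with two hetero atoms, and a hydrogen-bond acceptor is lost.

No measured pair among these compounds shows a step of this kind, so the expectation rests on the change alone. The step of a 1.5-fold higher number from compound 1 to compound 4 (0.16 log units; within the scatter) is expected to be small, within the scatter or slightly toward weaker inhibition. Compound 4 is estimated at 45 nM, with a range from 12 nM to 170 nM.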

Compound 4, inhibition constant: 504 nM
Compound 4: middle estimate off by 11-fold (1.05 log units), on the low side; the whole stated range lies below it.
By their numbers in this assay, from the lowest: compound 1; then compounds 4 and 3 (each within the scatter of the next); then compound 2.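

In this assay, within the data shown here, this aromatic carbon proves sensitive to the choice of ring: pyridin-2-yl in place of 3-methyl-1,2-oxazol-5-yl gives a 16-fold higher number from compound 1 to compound 4 (1.21 log units; beyond the scatter) and is the first single-place step. The two groups have the same heavy-atom count, so that count alone does not set the number here. No measured evidence on the origin of this step is available.

The compounds shown leave open whether the methyl group or the five-membered ring accounts for the step. An unsubstituted 1,2-oxazol-5-yl or a methylpyridin-2-yl would separate the two.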